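The source may report more compounds than this note shows. Statements on the series, on what has been measured and on what is new or still open speak of the compounds shown alone.

Measured so far:
- compound 1, `CCCOC(=O)Nc1ccc([Se]C#N)cc1` — 68800 nM
- compound 2, `CC(C)COC(=O)Nc1ccc([Se]C#N)cc1` — 68700 nM
- compound 3, `C=CCOC(=O)Nc1ccc([Se]C#N)cc1` — 68600 nM

All three share the same core and differ only in the chain that sits on the carbamate oxygen. In a functional assay on CCRF-CEM cells (Homo sapiens) for cytotoxicity, read by MTT assay, with a stated time of 72 h (on this read-out higher numbers stand for lower toxicity in this test and lower numbers for higher toxicity in this test), compound 3 gives 68600 nM, and the steps reaching it are flat: a 1.0-fold lower number from compound 1 to compound 3 (0.00 log units; within the scatter) and a 1.0-fold lower number from compound 2 to compound 3 (0.00 log units; within the scatter). Likewise a 1.0-fold lower number from compound 1 to compound 2 (0.00 log units; within the scatter). Within these three compounds, then, changing that chain has not moved the number beyond the scatter, and no compound can be called more or less toxic than another.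

Compound 4, `CCCCCCOC(=O)Nc1ccc([Se]C#N)cc1`, continues in the same place: pentyl in place of vinyl on a saturated chain carbon bound to an oxygen next to a carbonyl group. The measured steps that bear on it are the three just named, each of them within the scatter, although none of them adds as many carbons as this one does. On that basis the expectation for the step from compound 3 to compound 4 in this assay is no change beyond the scatter, a 1.0-fold higher number from compound 3 to compound 4 (0.00 log units; within the scatter). Compound 4 is therefore estimated at 68700 nM, with a range from 30000 nM to 150000 nM.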

Compound 4, concentration lethal to 50% of the cells: 72700 nM
Beside the measured number, compound 4's estimate is 1.1-fold (0.02 log units) below it; the range from low to high includes it.
By their numbers in this assay, from the lowest: compounds 3, 2, 1 and 4 (each within the scatter of the next).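

In this assay the hexyl chain of compound 4 brings no real shift: there is a 1.1-fold higher number from compound 3 to compound 4 (0.03 log units; within the scatter) and likewise a 1.1-fold higher number from compound 2 to compound 4 (0.02 log units; within the scatter) and a 1.1-fold higher number from compound 1 to compound 4 (0.02 log units; within the scatter), with every step inside the scatter. Among the compounds shown here, this place, on a saturated chain carbon bound to an oxygen next to a carbonyl group, therefore takes a larger addition of carbon than the earlier steps tried, and going from allyl to hexyl, which also removes the double bond, leaves the number flat as well. Nothing available explains why the chain makes so little difference.

As far as these compounds go, all four chains contain only carbon and hydrogen, so it remains open whether a chain carrying an amine or a carboxylic acid, a phenyl ring or a much longer chain would move the number. Also open, from the compounds shown here alone, is whether a change to the shared core would stay as flat, since only the chain varies here.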